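Compound 4 Takes a Thioamide Where Compound 3 Has an Amidine

This account rests on a few compounds, and the source may have more. Where it says the series, first, only, none or still open, it means among the compounds named here.

Three compounds with measurements frame the step. Compound 1 `CC(=O)c1ccccc1OCc1ccc2c(c1)=[N+]([O-])C(C)(C)[N+]=2[O-]` gives < 50 uM in an ADME assay on cells (Erythrocyte, Homo sapiens), read by spectrophotometry and hemolysis, with a stated time of 24 h (a higher number here means a weaker inhibitor, a lower number a stronger inhibitor), and that entry is a limit of the assay rather than a number (the limit of < 50 uM in this assay, at which 1 of the 3 values shown sits). Compound 2 `C=CCNC(=S)N/N=C/c1cccc(OCc2ccc3no[n+]([O-])c3c2)c1` gives "nd(insoluble)" (no result reported) in this assay, so no value stands for it. Among the measured compounds shown here, compound 3 `CC1(C)[N+]([O-])=c2ccc(COc3ccccc3/C=N\NC(=N)N)cc2=[N+]1[O-]` gives 114 uM in this assay, the only single number among the three. For the measured compounds named here, the one measured step, an at least 2.2-fold higher number from compound 1 to compound 3 (0.35 log units; beyond the scatter), concerns a change on an aromatic carbon and is therefore not the change now in view.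

Compound 4 `CC1(C)[N+]([O-])=c2ccc(COc3ccccc3/C=N\NC(N)=S)cc2=[N+]1[O-]` differs from compound 3 at one place: a group of 3 heavy atoms (1 carbon, 1 nitrogen, 1 sulfur; no ring) in place of a group of 3 heavy atoms (1 carbon, 2 nitrogen; no ring), on an amine nitrogen. No measured step alters the group on the amine nitrogen, so there is nothing among the shown numbers that speaks for a shift in either direction. Compound 4 is therefore expected to stay with compound 3 within the usual scatter, and the step of a 1.1-fold lower number from compound 3 to compound 4 (0.06 log units; within the scatter) is an estimate of no real movement. The expected value for compound 4 in this assay is 100 uM, with a range from 40 uM to 250 uM.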

Compound 4, concentration for 50% inhibition: > 200 uM
Compound 4: a limit, no number; the forecaster's own chance of this, stated with the estimate: 20%; at least 2.0-fold (0.30 log units) between middle value and limit.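

The entry for compound 4 in this assay is a limit and not a number: the limit of > 200 uM in this assay, at which 1 of the 4 values shown sits. Exchanging the amidine for the thioamide on the amine nitrogen gives an at least 1.7-fold higher number from compound 3 to compound 4 (0.24 log units; that floor lies within the scatter), so this first change shown at this position sets only a floor, and that floor does not establish a shift. The wider step, an at least 4.0-fold higher number from compound 1 to compound 4 (0.60 log units; beyond the scatter), stands beyond the scatter and runs in the same direction as an at least 2.2-fold higher number from compound 1 to compound 3 (0.35 log units; beyond the scatter), so both chains on the aromatic carbon, the one ending in the amidine and the one ending in the thioamide, give a higher number than the acetyl group.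

From the compounds shown here alone, how far the true value of compound 4 lies past its limit remains open, and with it whether the thioamide and the amidine differ at all in this assay. Also open, going by these compounds, is how a urea, with a carbonyl in place of the carbon-sulfur double bond, or a methyl group on the terminal nitrogen of the thioamide would read in this assay.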